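From bromo to iodo at the assay limit

The source may report more compounds than this note shows. Statements on the series, on what has been measured and on what is new or still open speak of the compounds shown alone.

Measured in a functional assay on MDA-MB-468 cells (Homo sapiens) for antiproliferative activity; a higher number here means a weaker inhibitor, a lower number a stronger inhibitor:
Compound 1 `Nc1ccc(-c2nc3ccccc3s2)cc1Cl`: < 1 nM
Compound 2 `Nc1ccc(-c2nc3ccccc3s2)cc1Br`: < 1 nM

Compound 2 stands at < 1 nM, which is a limit of the assay and not a number. Compound 1 also stands at a limit, < 1 nM.

Compound 3 `Nc1ccc(-c2nc3ccccc3s2)cc1I` differs from compound 2 by a single change: iodo in place of bromo on an aromatic carbon. Among the measured compounds shown here, the only measured step that bears on this change is the earlier exchange of one halogen for another, a step that the two limits leave unreadable from compound 1 to compound 2. That step gives no size to carry forward, and all that can be read from the two compounds is the limit of < 1 nM in this assay, at which 2 of the 2 values shown sit.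

On that ground, no step beyond the scatter is expected in this assay, and no direction can be given. The estimated step is a step that the limit leaves unreadable from compound 2 to compound 3. Compound 3 is expected to be reported as a limit too. For compound 3 the estimated value is 0.5 nM, with an expected range of 0.1 nM to 2 nM.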

Compound 3, half-maximal inhibitory concentration: < 1 nM
Compound 3: only a limit was reported; the forecaster's own chance of this, stated with the estimate: 80%; the middle value lies beyond the limit too.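

In this assay no step can be read among compound 1, compound 2 and compound 3, because all of them stand at a limit: the limit of < 1 nM in this assay, at which 3 of the 3 values shown sit. The compounds shown leave open whether chloro, bromo and iodo differ at all in this read-out.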